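Series notes: arylalkylthio propargylamines and compound 3

The source may report more compounds than this note shows. Statements on the series, on what has been measured and on what is new or still open speak of the compounds shown alone.

The shared core of compound 1 `C#CCNC1CCc2c(SCCc3ccc(C(F)(F)F)cc3)cccc21` carries a propargylamine and a thioether-linked aryl chain. Among the compounds with values here, in an assay on isolated protein for inhibition of Amine oxidase [flavin-containing] B (Homo sapiens) (a higher number here means a weaker inhibitor, a lower number a stronger inhibitor), compound 1 gives 16100 nM, which is the highest of the two numbers measured so far. Within the data shown here, the only other measured member, compound 2 `C#CCNC1CCc2c(SCc3ccc(F)c(F)c3)cccc21`, has a shorter linker and a differently substituted ring; in this assay compound 2 gives 2650 nM, a lower number than that of compound 1 by a margin beyond the usual scatter. Compound 2 differs from compound 1 in more than one place, so its value is noted only for where it puts compound 1 in the series.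

Compound 3 `C#CCNC1CCc2c(SCCc3ccc(Cl)cc3)cccc21` has not yet been measured. Against compound 1 the change is chloro in place of trifluoromethyl on an aromatic carbon, a chloro in place of the trifluoromethyl on an aromatic carbon, para to a large group.

Among the measured compounds shown here, no comparable step between measured compounds is on record. The expected step from compound 1 to compound 3 is a 1.8-fold lower number from compound 1 to compound 3 (0.25 log units; within the scatter), a modest move toward a lower number, not far beyond the scatter. In this assay compound 3 is therefore estimated at 9000 nM, within a range of 3000 nM to 27000 nM.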

Compound 3, half-maximal inhibitory concentration: 10800 nM
Compound 3: the middle estimate sits 1.2-fold (0.08 log units) below what was measured, and the stated range covers the measured number.
By their numbers in this assay, from the lowest: compound 2; then compounds 3 and 1 (each within the scatter of the next).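

Within the data shown here, the step of a 1.5-fold lower number from compound 1 to compound 3 (0.17 log units; within the scatter) in this assay is the first comparison between compounds that differ in one place, and it lies within the usual scatter. At this position, on an aromatic carbon para to a large group, chloro in place of trifluoromethyl therefore produces no change that this assay can resolve, although 1 heavy atom replaces 4. Compound 1 and compound 3 stand level here, and no measurement on record bears on the reason for this.

From the compounds shown here alone, whether this tolerance extends to groups of a different kind at the same position, such as an amine, a carboxylic acid or a methoxy group, remains open, as does the outcome of leaving the aromatic carbon unsubstituted. Among these compounds, also open are the separate contributions of the chain and the ring substitution, since no single-place step yet isolates either one, and a longer chain between the sulfur and the aromatic ring has yet to enter the comparison.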